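The compounds below may be only part of what the source reports. "The series", "measured", "known", "first", "only" and "open" are said of these compounds alone.

Compound 1 `Cc1cc(NCc2ccccn2)n2ncc(Br)c2n1` gives 89300 nM in a physicochemical assay for solubility, read by HPLC, using the shake flask method, measured as kinetic solubility, with a stated time of 2 h, at pH 7.4; on this read-out lower numbers stand for lower solubility and higher numbers for higher solubility.
Compound 2 `Cc1cc(N(C)Cc2ccccn2)n2nc(C)c(-c3ccccc3)c2n1` gives 17500 nM.
Compound 3 `Cc1cc(OCc2ccccn2)n2nc(C)c(-c3ccccc3)c2n1` gives 25600 nM.

Among these three numbers compound 3 holds the second highest. Compound 2 sits within the scatter of compound 3, so the two cannot be told apart. Compound 1 sits beyond the scatter, with the higher number of that pair. Compound 4 `Cc1cc(NCc2nccs2)n2nc(C)c(-c3ccccc3)c2n1` has not yet been measured. It differs from compound 3 in one place: ((1,3-thiazol-2-yl)methyl)amino in place of (pyridin-2-yl)methoxy on an aromatic carbon. Going by the values given here, no pair of measured compounds shows this change on its own, so there is no measured step to lean on. The expected step from compound 3 to compound 4 in this assay, a 1.2-fold higher number from compound 3 to compound 4 (0.07 log units; within the scatter), is small and not beyond the scatter. Compound 4 is therefore expected to give about 30000 nM, within a range from 12000 nM to 80000 nM.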

Compound 4, solubility: 108000 nM
Estimate against measurement, compound 4: 3.6-fold (0.56 log units) below; measured number above the stated range.
By their numbers in this assay, from the lowest: compounds 2 and 3 (each within the scatter of the next); then compounds 1 and 4 (each within the scatter of the next).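

In this assay, going by these compounds alone, putting ((1,3-thiazol-2-yl)methyl)amino in place of (pyridin-2-yl)methoxy on this aromatic carbon gives a 4.2-fold higher number from compound 3 to compound 4 (0.63 log units; beyond the scatter) and so provides the first readable step at this position. The step lies beyond the scatter, showing that a change at this one place can shift the read-out clearly on an otherwise unchanged molecule. No measurement shown explains this rise.

From the compounds shown here alone, the linking atom and the ring change together, so their separate shares remain unknown. Going by these compounds, how a carboxylic acid or a morpholine on this carbon would compare also remains open.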